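Methoxy for Chloro on Two Porcupine Inhibitor Cores

A few compounds are considered here, and "the series" means these few. Any claim that something is new, unique, unknown or untested is made for them only; others in the source may bear on it.

Measured compounds:
compound 1, `O=C(CSc1nc2c(c(=O)n1-c1ccccc1)SCC2)Nc1nc2ccc(Cl)cc2s1`, 40 nM
compound 2, `COc1ccc2nc(NC(=O)CSc3nc4c(c(=O)n3-c3ccccc3)SCC4)sc2c1`, 40 nM
compound 3, `O=C(CNC(=O)c1nn(-c2ccc(F)cc2)c(=O)c2ccccc12)Nc1nc2ccc(Cl)cc2s1`, 25 nM

In an assay on L cells for inhibition of Protein-serine O-palmitoleoyltransferase porcupine (Mus musculus), read by reporter gene assay, with a stated time of 24 h (a lower number here means that less compound is needed, a higher number that more compound is needed for the effect), compound 1 gives 40 nM and compound 2 gives 40 nM. The two share one core and differ only by methoxy in place of chloro on an aromatic carbon, and the step of no change at the digits printed from compound 1 to compound 2 (within the scatter) shows this change to be neutral here. Compound 3 is built on a different core; the difference between the two cores is not broken down here. In this assay compound 3 gives 25 nM, and its values and those of compound 1 and compound 2 all lie within the scatter of one another.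

Compound 4, `COc1ccc2nc(NC(=O)CNC(=O)c3nn(-c4ccc(F)cc4)c(=O)c4ccccc34)sc2c1`, has not yet been measured. It carries the same change on the core of compound 3: methoxy in place of chloro on an aromatic carbon. The same change was made from compound 1 to compound 2, so the step from compound 3 to compound 4 is expected to be no change at the digits printed from compound 3 to compound 4 (within the scatter), resting on the earlier step, because no change at the digits printed from compound 1 to compound 2 (within the scatter) showed no change. For compound 4 the expected value in this assay is 25 nM, between 12 nM and 50 nM.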

Compound 4, half-maximal effective concentration: 90 nM
Estimate against measurement, compound 4: 3.6-fold (0.56 log units) below; the measured number lies above the stated range.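

In this assay, methoxy in place of chloro gave no change at the digits printed from compound 1 to compound 2 (within the scatter) on one core but a 3.6-fold higher number from compound 3 to compound 4 (0.56 log units; beyond the scatter) on the other. Set side by side, the two steps do not agree: the same change on two cores in this assay, no change at the digits printed (within the scatter) from compound 1 to compound 2 and a 3.6-fold higher number (0.56 log units; beyond the scatter) from compound 3 to compound 4, 3.6-fold (0.56 log units) apart, beyond the scatter of two such steps. This shows that, for these two pairs, a neutral result for this change on one core did not carry over to the other, but it does not show which part of the cores is responsible, nor does a single pair on each core show how the change would behave across the wider series.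

The compounds shown leave open how other groups in place of chloro on the 1,3-benzothiazol-2-yl unit, such as fluoro, methyl or an amine, would behave on each core. They also leave open whether methoxy for chloro would give a step like the first or like the second on a third core, and which of the parts that differ between the two cores matters.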